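Replacing 3-bromophenyl with 4-methoxyphenyl in compound 4

The source may hold more compounds than are shown below. What is called first, only, known or untested is meant among the compounds shown, and "the series" means these compounds.

Compound 1 `COc1ccccc1/C=C/C(=O)OC/C=C/c1cc(OC)c(OC)cc1OC`: 101 umol/kg
Compound 2 `COc1cc(OC)c(OC)cc1/C=C/COC(=O)/C=C/c1ccc(Br)cc1`: 143 umol/kg
Compound 3 `COc1cc(OC)c(OC)cc1/C=C/COC(=O)/C=C/c1cccc(Br)c1`: 175 umol/kg

The three compounds were tested in a functional assay on the whole organism (strain Kunming) with Mus musculus as the target, with a stated time of 0.5 h; a higher number here means that more compound is needed for the effect, a lower number that less compound is needed. There compound 3 gives 175 umol/kg, a value within the scatter of those of compound 1 and compound 2.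

The next compound is compound 4 `COc1ccc(/C=C/C(=O)OC/C=C/c2cc(OC)c(OC)cc2OC)cc1`, which has not yet been measured. Its structure differs from that of compound 3 in one place: 4-methoxyphenyl in place of 3-bromophenyl on a double-bonded chain carbon bound to a double-bonded chain carbon. The 4-methoxyphenyl takes the place of 3-bromophenyl on a double-bonded chain carbon bound to a double-bonded chain carbon.

Three measured steps exchange the group at this same place. The first is a 1.4-fold higher number from compound 1 to compound 2 (0.15 log units; within the scatter). The second is a 1.7-fold higher number from compound 1 to compound 3 (0.24 log units; within the scatter). The third is a 1.2-fold higher number from compound 2 to compound 3 (0.09 log units; within the scatter). None of them leaves the scatter, whether a methoxyphenyl gives way to a bromophenyl or one bromophenyl gives way to the other. No step beyond the scatter is therefore expected in this assay, and no direction can be favoured. The estimated step is a 1.3-fold lower number from compound 3 to compound 4 (0.11 log units; within the scatter). For compound 4 the expected value is 135 umol/kg, with an estimated range of 75 umol/kg to 240 umol/kg.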

Compound 4, dose for half-maximal effect: 184 umol/kg
Estimate against measurement, compound 4: 1.4-fold (0.13 log units) below; the range from low to high includes it.
By their numbers in this assay, from the lowest: compounds 1, 2, 3 and 4 (each within the scatter of the next).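

In this assay, 4-methoxyphenyl in place of 3-bromophenyl (a 1.1-fold higher number from compound 3 to compound 4 (0.02 log units; within the scatter)) and methoxy in place of bromo on an aromatic carbon (a 1.3-fold higher number from compound 2 to compound 4 (0.11 log units; within the scatter)) both stay within the scatter, so this read-out does not separate the methoxyphenyl group of compound 4 from either bromophenyl group. The series now also holds a change of the methoxy-bearing group alone: 4-methoxyphenyl in place of 2-methoxyphenyl (a 1.8-fold higher number from compound 1 to compound 4 (0.26 log units; within the scatter)) stays within the scatter as well, which puts all four groups on this double-bonded chain carbon within the scatter of one another. Nothing at hand explains why these exchanges leave the values so close.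

On these data alone, all four groups are substituted phenyl rings, so it remains open whether an aminophenyl group, a phenyl ring carrying a carboxylic acid or a pyridine ring at this place would give a step beyond the scatter. As far as these compounds go, it is equally open whether the same lack of separation would hold with a changed shared core, for instance with an amide in place of its ester.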